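This account rests on a few compounds, and the source may have more. Where it says the series, first, only, none or still open, it means among the compounds named here.

Measured in a functional assay on MDA-MB-231 cells (Homo sapiens) for antiproliferative activity, read by MTT assay, with a stated time of 72 h; on this read-out higher numbers stand for weaker inhibition and lower numbers for stronger inhibition:
- compound 1 `CC1=CC[C@H]2[C@H](CC[C@]2(C)O)C(C)(C)[C@@H]1CC[C@H]1[C@]2(C)CC[C@H](OC(=O)CCC(=O)O)C(C)(C)O[C@H]2CC[C@@]1(C)O`: 27900 nM
- compound 2 `CC1=CC[C@H]2[C@@H]1CC=C(C)[C@@H](CC[C@H]1[C@]3(C)CC[C@H](OC(=O)CCC(=O)O)C(C)(C)O[C@H]3CC[C@@]1(C)O)C2(C)C`: 29600 nM
- compound 3 `CC1=CC[C@H]2[C@@H]1CC=C(C)[C@@H](CC[C@H]1[C@]3(C)CC[C@H](OC(=O)c4ccc(Cl)cc4)C(C)(C)O[C@H]3CC[C@@]1(C)O)C2(C)C`: 12700 nM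

Compound 1 and compound 2 lie within the usual scatter of each other, and compound 3 shows a lower number than either. Compound 4 `CC1=CC[C@H]2[C@H](CC[C@]2(C)O)C(C)(C)[C@@H]1CC[C@H]1[C@]2(C)CC[C@H](OCc3ccccc3)C(C)(C)O[C@H]2CC[C@@]1(C)O` differs from compound 1 in one place: benzyl in place of (2-carboxyethyl)carbonyl on an oxygen on a saturated carbon. Among the measured compounds shown here, the only measured step that bears on this is a 2.3-fold lower number from compound 2 to compound 3 (0.37 log units; beyond the scatter), where 2-carboxyethyl also left and an aromatic ring entered. That step was modest, and the core of compound 1 differs from the one it was measured on. For the measured compounds named here, no measured step removes the carbonyl as well. A similarly modest fall in this assay is therefore expected, and the expected step is a 2.0-fold lower number from compound 1 to compound 4 (0.30 log units; within the scatter). For compound 4 the estimated value is 14000 nM, with an expected range of 6000 nM to 30000 nM.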

Compound 4, half-maximal inhibitory concentration: 29100 nM
Compound 4: middle estimate off by 2.1-fold (0.32 log units), on the low side; measured number inside the range.
By their numbers in this assay, from the lowest: compound 3; then compounds 1, 4 and 2 (each within the scatter of the next).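

In this assay, compound 1 with (2-carboxyethyl)carbonyl and compound 4 with benzyl on this oxygen stand level, with a 1.0-fold higher number from compound 1 to compound 4 (0.02 log units; within the scatter), so on this core the carboxylic acid and carbonyl can be replaced by an all-carbon group without a measurable shift. An aromatic ring entering here therefore does not by itself bring a step like a 2.3-fold lower number from compound 2 to compound 3 (0.37 log units; beyond the scatter), which was measured on a different core. Nothing measured here explains this result.

Going by these compounds, whether an amine or a longer chain on this oxygen would shift the number remains open. So does whether the 4-chlorophenyl carbonyl of compound 3 would give a lower number on the core of compound 1.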